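This account rests on a few compounds, and the source may have more. Where it says the series, first, only, none or still open, it means among the compounds named here.

For the measured compounds named here, compound 2 `O=C1COc2ccc(-c3nn(-c4ccc(Cl)cc4)cc3-c3ccccc3)cc2N1` is one of two compounds measured in a functional assay on DLD-1 cells (Homo sapiens) for cytotoxicity, read by colorimetric assay and MTT assay, with a stated time of 3 days, tested at 20 uM; a higher number here means a weaker effect of the compound at the concentration tested, a lower number a stronger effect. In this assay compound 2 gives 47.1%, which is the lower of the two numbers. The other, compound 1 `Cc1ccccc1-n1cc(-c2ccccc2)c(-c2ccc3c(c2)NC(=O)CO3)n1`, gives 62.9% in this assay. Going by the values given here, the one measured step, a number 15.8 percentage points lower from compound 1 to compound 2 (beyond the scatter), came with 4-chlorophenyl in place of 2-methylphenyl on an aromatic nitrogen.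

Compound 3 `O=C1COc2ccc(-c3nn(-c4ccc(F)cc4)cc3-c3ccccc3)cc2N1` differs from compound 2 in one place: fluoro in place of chloro on an aromatic carbon. Among the compounds with values here, no measured step changes one halogen for another on that ring, so the step from compound 1 to compound 2 bears only loosely on it, having swapped the whole substituted phenyl group rather than a single halogen. Because compound 2 gives 47.1%, the expected step of a number 4.9 percentage points higher from compound 2 to compound 3 (within the scatter) is none beyond the scatter. Compound 3 is therefore estimated at 52% in this assay, with a range from 38% to 68%.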

Compound 3, a percentage reported as activity, at one concentration (the size of the read-out at that concentration, not a potency): 45.2%
Beside the measured number, compound 3's estimate is 6.8 percentage points above it, within the range that was stated.
By their numbers in this assay, from the lowest: compounds 3 and 2 (each within the scatter of the next); then compound 1.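

In this assay the change from chloro to fluoro at this place gives a number 1.9 percentage points lower from compound 2 to compound 3 (within the scatter) and so leaves the two halogen compounds without any order between them. The new comparison also gives a number 17.7 percentage points lower from compound 1 to compound 3 (beyond the scatter) and thus shows that the step away from the 2-methylphenyl group of compound 1 is not tied to chloro alone, since the 4-fluorophenyl and 4-chlorophenyl groups both read clear of it. No measurement shown here explains the size of either step.

As far as these compounds go, it remains open how an amine or a carboxylic acid would read in place of the halogen on this aromatic ring. From the compounds shown here alone, it is also open whether a longer chain on the aromatic nitrogen could stand in for the substituted phenyl group altogether.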